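The source may report more compounds than this note shows. Statements on the series, on what has been measured and on what is new or still open speak of the compounds shown alone.

Working notes on the series in an ADME assay on microsomes from liver (Homo sapiens) for metabolic stability; on this read-out lower numbers stand for slow clearance and higher numbers for fast clearance.

Compound 3 is `O=c1n(Cc2nc(-c3ncccn3)cn2CCCCO)c2cnccc2n1C1CC1`. In this assay compound 3 gives < 8 mL.min-1.g-1, which is a limit of the assay and not a number. Its neighbours in the series are compound 1, `O=c1n(Cc2nc(-c3nccs3)cn2CCCCO)c2cnccc2n1C1CC1`, and compound 2, `COCc1cn(CCCCO)c(Cn2c(=O)n(C3CC3)c3ccncc32)n1`. Compound 1 likewise sits at a limit of the assay, < 8 mL.min-1.g-1. For the measured compounds named here, compound 2 is the only member with a number, giving 9 mL.min-1.g-1 in this assay. The measured steps are small or unreadable: an at least 1.1-fold higher number from compound 1 to compound 2 (0.05 log units; that floor lies within the scatter), an at least 1.1-fold lower number from compound 2 to compound 3 (0.05 log units; that floor lies within the scatter), and a step that the two limits leave unreadable from compound 1 to compound 3, the last unreadable because of the limit of < 8 mL.min-1.g-1 in this assay, at which 2 of the 3 values shown sit. All three values, then, lie close to the floor of this assay.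

Compound 4 is `Cn1ccnc1-c1cn(CCCCO)c(Cn2c(=O)n(C3CC3)c3ccncc32)n1`. The change from compound 3 is 1-methyl-1H-imidazol-2-yl in place of pyrimidin-2-yl on an aromatic carbon. The nearest measured comparison is the exchange of the six-membered pyrimidin-2-yl for either 1,3-thiazol-2-yl or methoxymethyl at the same aromatic carbon, and neither moved this assay beyond its scatter. On that basis compound 4 is expected to show a step that the limit leaves unreadable from compound 3 to compound 4, that is, no step beyond the scatter. The estimate for compound 4 in this assay is 7 mL.min-1.g-1, with a range from 3 mL.min-1.g-1 to 16 mL.min-1.g-1, and a fair chance that only a limit is again reported.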

Compound 4, intrinsic clearance in microsomes: < 8 mL.min-1.g-1
Compound 4: no number, only a limit (the forecaster's own chance of this, stated with the estimate: 50%); the middle value is on the limit's open side.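

With 1-methyl-1H-imidazol-2-yl on this aromatic carbon, compound 4 joins compound 1 and compound 3 at the limit, so a five-membered aromatic ring bearing a methyl group gives no readable number here, just as the 1,3-thiazol-2-yl and pyrimidin-2-yl groups do not. Against compound 2, the only member with a number, this assay shows an at least 1.1-fold lower number from compound 2 to compound 4 (0.05 log units; that floor lies within the scatter), so even this comparison separates methoxymethyl from the new group by nothing beyond the scatter. The steps from compound 1 and from compound 3 to compound 4 cannot be read, because both ends of each rest on the same limit: the limit of < 8 mL.min-1.g-1 in this assay, at which 3 of the 4 values shown sit.

As far as these compounds go, how far the three ring-bearing compounds lie under that limit, and whether they differ from one another at all, stays open. Also open is whether a group of another kind on this aromatic carbon, such as a carboxylic acid or a primary amine on a longer chain, would move the read-out beyond the scatter, as all groups shown here leave it close to the floor of the assay.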